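Solubility notes: a new ring on the chain carbon

The compounds below may be only part of what the source reports. "The series", "measured", "known", "first", "only" and "open" are said of these compounds alone.

Measured so far:
Compound 1 `COC(=O)C1=C(C)NC(c2nccs2)=NC1(C)c1ccc(F)cc1` gives 22 ug/mL in a physicochemical assay for solubility, read by HPLC, in phosphate buffer, at pH 6.5; on this read-out higher numbers stand for higher solubility and lower numbers for lower solubility.
Compound 2 `COC(=O)C1=C(CN2CCOCC2=O)NC(c2nccs2)=NC1(C)c1ccc(F)cc1` gives 440 ug/mL in this assay.

Among the compounds with values here, compound 2 stands highest of the two numbers in this assay; its only neighbour is compound 1, with a 20-fold higher number from compound 1 to compound 2 (1.30 log units; beyond the scatter). Compound 3 `COC(=O)C1=C(CN2CCC(C(F)(F)F)C2)NC(c2nccs2)=NC1(C)c1ccc(F)cc1` is not yet measured; it differs from compound 2 by 3-(trifluoromethyl)pyrrolidin-1-yl in place of 3-oxomorpholin-4-yl on a saturated chain carbon bound to a double-bonded ring carbon. Within the data shown here, the sole step bearing on this position is that from compound 1 to compound 2, and it was large, so the position clearly matters. Among the measured compounds shown here, no measured compound carries the entering group, so the direction is uncertain. A move down, a 7.3-fold lower number from compound 2 to compound 3 (0.87 log units; beyond the scatter), is expected. Compound 3 is estimated at 60 ug/mL, within 15 ug/mL to 250 ug/mL.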

Compound 3, solubility: 13 ug/mL
Beside the measured number, compound 3's estimate is 4.6-fold (0.66 log units) above it; the measured number lies below the stated range.
By their numbers in this assay, from the lowest: compounds 3 and 1 (each within the scatter of the next); then compound 2.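

a 34-fold lower number from compound 2 to compound 3 (1.53 log units; beyond the scatter) and a 1.7-fold lower number from compound 1 to compound 3 (0.23 log units; within the scatter) show that in this assay not every ring on a saturated chain carbon bound to a double-bonded ring carbon lifts the number. The gain seen with 3-oxomorpholin-4-yl does not carry over to 3-(trifluoromethyl)pyrrolidin-1-yl, which stays within the scatter of the hydrogen in compound 1. No measured evidence accounts for the gap between these two rings.

Open, on these data alone, is whether a morpholine without the carbonyl, or a pyrrolidine without the trifluoromethyl, would stand nearer compound 2 or compound 3.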